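The source may hold more compounds than are shown below. What is called first, only, known or untested is meant among the compounds shown, and "the series" means these compounds.

Working notes on a small series built on a shared core, read in a functional assay on L1210 cells (Mus musculus); a higher number here means a weaker inhibitor, a lower number a stronger inhibitor. Compound 1 `O=C(/C=C/c1ccc(Cl)c(Cl)c1)Oc1ccc(/C=C2\CCCCC2=O)cc1` gives 64800 nM, compound 2 `CN(C)CC1CCC/C(=C\c2ccc(OC(=O)/C=C/c3ccc(Br)cc3)cc2)C1=O` gives 1780 nM, and compound 3 `O=C1CCCC/C1=C\c1ccc(OC(=O)c2ccc(Cl)cc2)cc1` gives 3330 nM. Compound 3 lies within the scatter of compound 2, while compound 1 carries a higher number, beyond the scatter of compound 3.

Compound 4 `Cc1ccc(C(=O)Oc2ccc(/C=C3\CCCCC3=O)cc2)cc1` is still unmeasured and departs from compound 3 in one place: methyl in place of chloro on an aromatic carbon, para to a large group. Among the measured compounds shown here, no two measured compounds differ in one place only, so the series offers no direct precedent for this exchange. The expectation therefore starts from compound 3 at 3330 nM, and no shift beyond the scatter is anticipated. The estimated step of a 1.4-fold higher number from compound 3 to compound 4 (0.13 log units; within the scatter) is expected to stay within the scatter, with a slightly higher number at most. For compound 4 the expected value is 4500 nM, with an estimated range of 1500 nM to 14000 nM.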

Compound 4, half-maximal inhibitory concentration: 44800 nM
Compound 4: middle estimate off by 10-fold (1.00 log units), on the low side; the measured number lies above the stated range.
By their numbers in this assay, from the lowest: compounds 2 and 3 (each within the scatter of the next); then compounds 4 and 1 (each within the scatter of the next).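

In this assay, among the compounds shown here, the exchange of 4-chlorophenyl for 4-methylphenyl gives the first step between compounds that differ in one place, a 13-fold higher number from compound 3 to compound 4 (1.13 log units; beyond the scatter), so this site, para to a large group, is sensitive to which single heavy atom it carries. Chloro and methyl match in heavy-atom count, and neither adds a hydrogen-bond donor, a hydrogen-bond acceptor or a net charge, so these counts do not separate the two groups even though the numbers differ widely. Nothing at hand bears on the origin of this step.

This one pair cannot show whether chloro raises the inhibition or methyl lowers it. Fluoro, methoxy or plain hydrogen at the same site would be needed to tell which group sets the step, and whether it holds beyond this pair remains open.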